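The compounds below may be only part of what the source reports. "The series", "measured", "known", "first", "only" and "open" are said of these compounds alone.

Compound 3, drawn as `COc1ccc(CCC(=O)/C=C/[C@H](O)Cc2ccccc2)cc1OC`, gives 11100 nM in a functional assay on COLO 205 cells (Homo sapiens) for antiproliferative activity, read by MTT assay, with a stated time of 48 h; a lower number here means a stronger inhibitor, a higher number a weaker inhibitor. Among the three compounds measured in this assay, compound 3 stands lowest: compound 1, drawn as `O=C(/C=C/[C@H](O)Cc1ccccc1)CCc1ccccc1`, gives 195000 nM in this assay, and compound 2, drawn as `O=C(/C=C/[C@@H](O)Cc1ccccc1)CCc1ccccc1`, gives 498000 nM in this assay.

The step under consideration leads from compound 3 to compound 4, drawn as `COc1ccc(CCC(=O)/C=C/[C@@H](O)Cc2ccccc2)cc1OC`. The change is the two compounds have the same atoms and bonds and differ only in configuration as drawn: 1 of 2 stereo elements differ; a stereocentre at a saturated chain carbon is drawn R in compound 3 and S in compound 4. Going by the values given here, only one measured step bears on this change: that between compound 1 and compound 2, because the fact that compounds 1 and 2 differ only in the configuration as drawn those two compounds offer the same inversion at the same stereocentre, on a core that lacks the two methoxy groups of compound 3 and compound 4. In this assay that inversion gave a 2.6-fold higher number from compound 1 to compound 2 (0.41 log units; beyond the scatter), a modest rise in the number. Carrying this precedent over, compound 4 is expected to sit at a higher number than compound 3, with the step estimated as a 2.5-fold higher number from compound 3 to compound 4 (0.40 log units; beyond the scatter). The estimate for compound 4 in this assay is therefore 28000 nM, with a range from 12000 nM to 70000 nM; the range is kept wide because a 2.6-fold higher number from compound 1 to compound 2 (0.41 log units; beyond the scatter) rests on a single pair.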

Compound 4, half-maximal inhibitory concentration: 7210 nM
The estimate for compound 4 lay 3.9-fold (0.59 log units) above the measured number, outside the stated range (below it).
By their numbers in this assay, from the lowest: compounds 4 and 3 (each within the scatter of the next); then compound 1; then compound 2.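

In this assay, inverting the saturated chain carbon, drawn R in compound 3 and S in compound 4, gives a 1.5-fold lower number from compound 3 to compound 4 (0.19 log units; within the scatter). On the core carrying the two methoxy groups, this configuration therefore does not separate the two compounds, whereas on the core without those groups the same inversion gave a 2.6-fold higher number from compound 1 to compound 2 (0.41 log units; beyond the scatter), a step beyond the scatter. The stereocentre thus registers in one of the two pairs and not in the other, and in the later pair no other structural change enters the comparison: the fact that compounds 3 and 4 differ only in the configuration as drawn.

From the compounds shown here alone, with only these two pairs, it remains open whether the inversion would register on a core bearing a single methoxy group, or a carboxylic acid in place of the two methoxy groups. Also unsettled is how an amine in place of the hydroxyl at this stereocentre would read in either configuration, and whether the contrast between the two pairs would persist with a longer chain between the carbonyl and the ring bearing the methoxy groups.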